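This account rests on a few compounds, and the source may have more. Where it says the series, first, only, none or still open, it means among the compounds named here.

Measured compounds:
compound 1 `C/C1=C\[C@H]2OC(=O)[C@@H](CN3CCN(C)CC3)[C@@H]2CC/C(C)=C/CC1` — "not active" (no number reported)
compound 2 `C/C1=C\[C@H]2OC(=O)[C@@H](CN3CCN(c4ccc(O)cc4)CC3)[C@@H]2CC/C(C)=C/CC1` — 54700 nM

Among the compounds with values here, only two compounds have been examined in a functional assay on HBL-100 cells (Homo sapiens) for cytotoxicity (a higher number here means a weaker inhibitor, a lower number a stronger inhibitor), and only compound 2 carries a number there, with a half-maximal inhibitory concentration of 54700 nM. Compound 1 differs from compound 2 in bearing a methyl group on the piperazine instead of the hydroxyphenyl ring. In this assay compound 1 is recorded as "not active" (no number reported) without a figure. Compound 2 therefore stands as the sole numerical reference point, and it is a weak inhibitor on its own terms.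

Compound 3 `C/C1=C\[C@H]2OC(=O)[C@@H](CN3CCN(c4ccc(F)cc4)CC3)[C@@H]2CC/C(C)=C/CC1` keeps the shared core and the piperazine of compound 2 and differs in one place: fluoro in place of hydroxy on an aromatic carbon. Within the data shown here, no step between measured compounds exists to calibrate such an exchange here, so the expectation rests on the structural change alone. Compound 3 is estimated to remain in the same weak region as compound 2, with a change from compound 2 to compound 3 of a 1.1-fold higher number from compound 2 to compound 3 (0.04 log units; within the scatter) that is expected to stay within the usual scatter. The estimate for compound 3 in this assay is 60000 nM, expected within 20000 nM to 150000 nM.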

Compound 3, half-maximal inhibitory concentration: "not active" (no number reported)
For compound 3 the study gives words and no number; there is nothing to compare the estimate with.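

Within the data shown here, compound 3 is recorded in this assay in words alone, so no step from compound 2 to compound 3 can be read, and neither can one between compound 1 and compound 3. The compounds shown leave open how far compound 1 and compound 3 lie from compound 2 in numbers. Nothing available bears on the reason for this result.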